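Methyl for Chloro in Two Weak Urea Analogues

The source may hold more compounds than are shown below. What is called first, only, known or untested is meant among the compounds shown, and "the series" means these compounds.

Measured so far in a functional assay on MCF7 cells (Homo sapiens) for cytotoxicity, read by MTT assay, with a stated time of 48 h; a lower number here means a stronger inhibitor, a higher number a weaker inhibitor:
compound 1, `COc1ccc(CN(C(=O)Nc2ccc(Cl)cc2)n2cnnc2)cc1OC`: > 50000 nM
compound 2, `COc1cc(CN(C(=O)Nc2cc(C(F)(F)F)cc(C(F)(F)F)c2)n2cnnc2)cc(OC)c1OC`: 23800 nM

Compound 1 sits at the limit of this assay, > 50000 nM, which is a limit and not a number. In this assay compound 2 gives 23800 nM. Among the compounds with values here, the two differ at more than one place, so no single step connects them; their values stand side by side, with the limit of > 50000 nM in this assay, at which 1 of the 2 values shown sits, marking where compound 1 sits.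

Compound 3, `COc1ccc(CN(C(=O)Nc2ccc(C)cc2)n2cnnc2)cc1OC`, is yet to be measured in this assay. It differs from compound 1 by methyl in place of chloro on an aromatic carbon, in words a methyl in place of chloro on an aromatic carbon. With compound 1 resting at the limit of > 50000 nM in this assay, at which 1 of the 2 values shown sits, no step beyond the scatter can be read downward from it. The step of a number no higher from compound 1 to compound 3 (the limit leaves the size open) is expected to stay within the scatter. Compound 3 is therefore expected to give about 50000 nM in this assay, between 15000 nM and 150000 nM, most likely again only as a limit.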

Compound 3, half-maximal inhibitory concentration: > 50000 nM
Compound 3 ended at the assay's limit; the forecaster's own chance of this, stated with the estimate: 60%; the middle value sits exactly at the limit.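

In this assay compound 3 gives > 50000 nM, which is a limit and not a number. Compound 1 gives > 50000 nM, also a limit, so no step can be read between compound 1 and compound 3. The compounds shown leave open whether methyl in place of chloro on an aromatic carbon changes the value at all.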